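Working notes: trifluoromethoxy on compound 3

A few compounds are considered here, and "the series" means these few. Any claim that something is new, unique, unknown or untested is made for them only; others in the source may bear on it.

Compound 1 `COc1cccc(NC(=O)c2nnn(Cc3ccc([S+](C)[O-])cc3)c2N)c1`: 1.3
Compound 2 `COc1cccc(NC(=O)c2nnn(Cc3ccc(C(C)C)cc3)c2N)c1`: 3.4
Compound 3 `COc1cccc(NC(=O)c2nnn(Cc3ccccc3)c2N)c1`: 2.6

In a physicochemical assay for lipophilicity, read by HPLC, measured as chromatographic lipophilicity, at pH 7.4 (a lower number here means a more polar compound, a higher number a more lipophilic compound), compound 3 stands second highest of the three at 2.6. The next compound is compound 4 `COc1cccc(NC(=O)c2nnn(Cc3ccc(OC(F)(F)F)cc3)c2N)c1`, with trifluoromethoxy in place of hydrogen on an aromatic carbon. Going by the values given here, no measured compound carries this group. The closest guide, read in reverse, is the modest step of a number 0.80 log units lower from compound 2 to compound 3 (beyond the scatter), for isopropyl. The large step of a number 1.30 log units higher from compound 1 to compound 3 (beyond the scatter) runs the opposite way for a group holding sulfur and oxygen, so it helps less. A modest rise in this assay is therefore expected. The expected step is a number 0.70 log units higher from compound 3 to compound 4 (beyond the scatter). Compound 4 is estimated at 3.3, with an expected range of 3 to 3.7.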

Compound 4, distribution coefficient: 3.6
The estimate for compound 4 lay 0.30 log units below the measured number; the measured number falls inside the stated range.
By their numbers in this assay, from the lowest: compound 1; then compound 3; then compounds 2 and 4 (each within the scatter of the next).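

In this assay trifluoromethoxy in place of hydrogen gives a number 1.00 log units higher from compound 3 to compound 4 (beyond the scatter) on this aromatic carbon, para to a large group. Trifluoromethoxy in place of isopropyl gives a number 0.20 log units higher from compound 2 to compound 4 (within the scatter) so the two groups are not told apart at this position, whereas replacing the group holding sulfur and oxygen gives a number 2.30 log units higher from compound 1 to compound 4 (beyond the scatter) and keeps that group well apart from both. Nothing available explains these steps.

On these data alone, how an amine, a carboxylic acid or a longer chain on this carbon would read against hydrogen stays open. As far as these compounds go, whether trifluoromethoxy gives a similar step on another carbon of the same ring also stays open.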